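The source may hold more compounds than are shown below. What is called first, only, known or untested is meant among the compounds shown, and "the series" means these compounds.

Working notes on the cinnamate series in a functional assay on the whole organism for inhibition, with Brassica rapa subsp. chinensis as the target, with a stated time of 3 days, tested at 100 ppm; on this read-out higher numbers stand for more inhibition of growth at the one concentration tested and lower numbers for less inhibition of growth.

Three compounds carry measured values. Compound 1 `CCc1ccccc1NC(=O)/C=C/c1ccccc1`, an anilide, gives 21%. Compound 2 `Cc1ccc(C(C)C)c(OC(=O)/C=C/c2ccc(C(C)C)cc2)c1`, a phenyl ester bearing an isopropyl group on the cinnamate ring, gives 30%. Compound 3 `Cc1ccc(OC(=O)/C=C/c2ccc(Cl)cc2)c(C(C)C)c1`, a phenyl ester with a chloro group on the cinnamate ring and a different substitution pattern on the phenol part, gives 18%. Compound 2 holds the highest number of the three; compound 1 sits within the scatter of it, so the two cannot be ranked against each other, whereas compound 3 lies beyond the scatter and lower than compound 2.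

Compound 4 `Cc1ccc(C(C)C)c(OC(=O)/C=C/c2ccc(Cl)cc2)c1` is not yet measured. It keeps the phenol part of compound 2 and differs from it only on the cinnamate ring: chloro in place of isopropyl on an aromatic carbon. For the measured compounds named here, no measured pair in the set isolates this exact change, so the size of the step is uncertain. Going by the values given here, the only guidance is that compound 3, which also carries the chloro group on the cinnamate ring, gives 18%, a lower number than compound 2. On that basis a decrease is expected, a number 10 percentage points lower from compound 2 to compound 4 (within the scatter), roughly at the edge of the scatter. Compound 4 is estimated at 20%, with a range from 8% to 32%.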

Compound 4, percent growth inhibition at one concentration: 24%
Estimate against measurement, compound 4: 4 percentage points below; low and high end bracket the measured number.
By their numbers in this assay, from the lowest: compounds 3, 1, 4 and 2 (each within the scatter of the next, the first and the last beyond it).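

In this assay, for the compounds shown here, chloro in place of isopropyl on an aromatic carbon, para to a large group, gives the first comparison that isolates one place: a number 6 percentage points lower from compound 2 to compound 4 (within the scatter), a step that does not separate the two compounds. At this position, then, exchanging a group of 3 heavy atoms for one of 1 heavy atom, neither with hydrogen-bond donors, hydrogen-bond acceptors or a net charge, produces no readable change at the one concentration tested. No evidence from any other kind of measurement bears on this result, so the closeness of the two values stays without an explanation.

Going by these compounds alone, whether this position responds to a group of another kind, such as an amine, a carboxylic acid, a methoxy group or a longer chain, stays open, since isopropyl and chloro are the only two groups compared here. Also open, going by these compounds, is whether chloro in place of isopropyl gives a similar step on a different core, such as the anilide of compound 1, or with the phenol part changed, since this single pair covers one background only.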